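The source may hold more compounds than are shown below. What is called first, only, known or untested is meant among the compounds shown, and "the series" means these compounds.

Compound 1, `OCC(O)Cn1nc2c(Br)c(Br)c(Br)c(Br)c2n1`: 8%
Compound 2, `OC(CCn1nc2c(Br)c(Br)c(Br)c(Br)c2n1)c1ccc(Br)cc1`: 0%

Both were run in a functional assay on MCF7 cells (Homo sapiens) for antiproliferative activity, read by MTT assay, with a stated time of 48 h, tested at 100 uM; a higher number here means a weaker effect of the compound at the concentration tested, a lower number a stronger effect. Compound 1 gives 8% and compound 2 gives 0%; the two numbers lie within the scatter of each other, so compound 2 is not set apart from compound 1. Compound 3, `OC(CCn1nc2c(Br)c(Br)c(Br)c(Br)c2n1)c1ccccc1`, remains to be measured. Its difference from compound 2: hydrogen in place of bromo on an aromatic carbon. Within the data shown here, only two measured points exist, both near the floor of the read-out, and no step between them is resolved, so for this change no step beyond the scatter is expected in this assay. The expected step is a number 5 percentage points higher from compound 2 to compound 3 (within the scatter). Compound 3 is estimated at 5%, range 0% to 20%.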

Compound 3, a percentage reported as activity, at one concentration (the size of the read-out at that concentration, not a potency): 0%
The estimate for compound 3 lay 5 percentage points above the measured number; low and high end bracket the measured number.
By their numbers in this assay, from the lowest: compounds 2, 3 and 1 (each within the scatter of the next).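

Among these compounds, the change from 4-bromophenyl to phenyl gives the first one-place comparison: this assay shows no change at the digits printed from compound 2 to compound 3 (within the scatter). The bromo on the aromatic carbon is therefore not required to hold the read-out at this level at the single concentration tested. No measurement available here speaks to the reason for this.

With both compounds at the floor of the read-out, a real difference between them could stay hidden at this concentration. Going by these compounds, whether an amine or a carboxylic acid in place of the bromo would move the read-out remains open.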